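A few compounds are considered here, and "the series" means these few. Any claim that something is new, unique, unknown or untested is made for them only; others in the source may bear on it.

In a functional assay on HEK293 cells (Homo sapiens) for cytotoxicity (a higher number here means that more compound is tolerated, a lower number that less compound is tolerated), compound 1 (`COc1ccc([C@H]2CC(=O)N(c3cccc([S+](C)[O-])c3)C2)cc1OC1CCCC1`) gives > 10000 nM as a limit. Compound 2 (`COc1ccc([C@H]2CC(=O)N(c3cccc(NCC4CCOC4)c3)C2)cc1OC1CCCC1`) gives > 10000 nM as a limit. Compound 3 (`COc1ccc([C@H]2CC(=O)N(c3cccc(NS(=O)(=O)c4cc(C)ccc4OC)c3)C2)cc1OC1CCCC1`) gives > 10000 nM as a limit and has no number of its own. For the measured compounds named here, the series so far therefore stands at the limit of > 10000 nM in this assay, at which 3 of the 3 values shown sit, and offers no measured value to work from.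

Compound 4 (`COc1ccc([C@H]2CC(=O)N(c3cccc(NS(=O)(=O)c4ccccc4Br)c3)C2)cc1OC1CCCC1`) carries 2-bromophenyl in place of 2-methoxy-5-methylphenyl on a sulfonyl sulfur is the full change from compound 3. The closest measured change is a step that the two limits leave unreadable from compound 2 to compound 3 and the other is a step that the two limits leave unreadable from compound 1 to compound 2 with neither giving a size or a direction. The expected step that the limit leaves unreadable from compound 3 to compound 4 is therefore none beyond the scatter, in no particular direction. Compound 4 is estimated at 15000 nM with an expected range of 7000 nM to 30000 nM and may well end up only as a limit.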

Compound 4, half-maximal cytotoxic concentration: > 10000 nM
Compound 4 was reported as a limit; the forecaster's own chance of this, stated with the estimate: 85%; the middle value is on the limit's open side.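

In this assay, for the compounds shown here, compound 4 gives > 10000 nM as a limit, so no step from compound 1, compound 2 or compound 3 to compound 4 can be read. Which change, if any, would give a measured value stays open, as the series stands at one limit: the limit of > 10000 nM in this assay, at which 4 of the 4 values shown sit.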